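The source may report more compounds than this note shows. Statements on the series, on what has been measured and on what is new or still open speak of the compounds shown alone.

Working notes on the series.

Compound 1 `Nc1ccccc1NC(=O)c1ccc(Cn2cnc3c(Nc4ccccc4)nc(Cl)nc32)cc1` carries the shared core with an unsubstituted anilino group; in a functional assay on NCI-H460 cells (Homo sapiens) for antiproliferative activity, read by CCK-8 assay, with a stated time of 72 h, tested at 2 uM (a lower number here means a weaker effect, a higher number a stronger effect of the compound at the concentration tested), compound 1 gives 42.7%. Compound 3 `Nc1ccccc1NC(=O)c1ccc(Cn2cnc3c(Nc4cccc(Cl)c4)nc(Cl)nc32)cc1` differs from compound 1 only by the change (chloro in place of hydrogen on an aromatic carbon), and in this assay compound 3 gives 10.3%, so that the step is a number 32.4 percentage points lower from compound 1 to compound 3 (beyond the scatter).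

Compound 2 `CCCCn1cnc2c(Nc3ccccc3)nc(NCOCc3ccc(C(=O)Nc4ccccc4N)cc3)nc21` has a different core; how the cores of compound 1 and compound 2 differ is not broken down here. In this assay compound 2 gives 27.7%, a number between those of compound 1 and compound 3.

Compound 4 `CCCCn1cnc2c(Nc3cccc(Cl)c3)nc(NCOCc3ccc(C(=O)Nc4ccccc4N)cc3)nc21` is not yet measured. It differs from compound 2 by chloro in place of hydrogen on an aromatic carbon, and the place described is the same, word for word, as for the change from compound 1 to compound 3, so it is taken as the same change on a different core. On that basis the step from compound 2 to compound 4 is expected to be downward and of similar size, a number 21.7 percentage points lower from compound 2 to compound 4 (beyond the scatter), because the earlier step was a number 32.4 percentage points lower from compound 1 to compound 3 (beyond the scatter); starting lower, compound 4 cannot fall as far. For compound 4 in this assay the estimate is 6%, expected to lie between -5% and 22%.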

Compound 4, a percentage reported as inhibition, at one concentration (the size of the read-out at that concentration, not a potency): 56.9%
Beside the measured number, compound 4's estimate is 50.9 percentage points below it, outside the stated range (above it).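

In this assay, going from phenyl to 3-chlorophenyl on the core of compound 2 gives a number 29.2 percentage points higher from compound 2 to compound 4 (beyond the scatter), whereas the same change on the core of compound 1 went downward. Set side by side, the two steps run in opposite directions: the same change on two cores in this assay, a number 32.4 percentage points lower (beyond the scatter) from compound 1 to compound 3 and a number 29.2 percentage points higher (beyond the scatter) from compound 2 to compound 4, 61.6 percentage points apart, beyond the scatter of two such steps

The change therefore does not carry from one core to the other in these two pairs, and a step read on one of these cores gives no guide to its direction on the other. The pairs do not show which part of the core decides the direction, nor how the change would behave on any third core.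

The compounds shown leave open which structural part of the core goes with the reversal, as the cores of compound 1 and compound 2 are compared here only as wholes. Also open, going by these compounds, is whether a fluoro or a methoxy group in the place of the chloro would follow the chloro on each core.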